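Aryl replacement on the shared core and microsomal clearance

The source may hold more compounds than are shown below. What is called first, only, known or untested is meant among the compounds shown, and "the series" means these compounds.

Three compounds on one core have been run in an ADME assay (liver) for metabolic stability, with Liver microsome (Homo sapiens) as the target, using microsomes and NADPH, with a stated time of 30 min, tested at 1 uM; on this read-out lower numbers stand for slow clearance and higher numbers for fast clearance. Compound 1 `CCn1cc(-c2cc(C(O)(C(F)(F)F)C(F)(F)F)cnc2N2CCN(S(=O)(=O)c3ccc(N)nc3)CC2)cn1` gives 20 mL.min-1.g-1, the lowest of the three numbers. Compound 2 `Nc1ccc(S(=O)(=O)N2CCN(c3ncc(C(O)(C(F)(F)F)C(F)(F)F)cc3-c3cccc(F)c3)CC2)cn1` gives 25 mL.min-1.g-1, and compound 3 `COc1cncc(-c2cc(C(O)(C(F)(F)F)C(F)(F)F)cnc2N2CCN(S(=O)(=O)c3ccc(N)nc3)CC2)c1` gives 44 mL.min-1.g-1. From compound 1 the steps are a 1.3-fold higher number from compound 1 to compound 2 (0.10 log units; within the scatter) and a 2.2-fold higher number from compound 1 to compound 3 (0.34 log units; beyond the scatter); between the other two, a 1.8-fold higher number from compound 2 to compound 3 (0.25 log units; within the scatter). Compound 4 `Cc1nc2cc(-c3cc(C(O)(C(F)(F)F)C(F)(F)F)cnc3N3CCN(S(=O)(=O)c4ccc(N)nc4)CC3)ccc2o1` alters the same position: 2-methyl-1,3-benzoxazol-5-yl in place of 1-ethyl-1H-pyrazol-4-yl on an aromatic carbon. Both measured replacements at this carbon raised the number or left it within the scatter, and the one that went beyond the scatter was modest. For compound 4 a step of similar size is therefore expected, a 2.0-fold higher number from compound 1 to compound 4 (0.30 log units; within the scatter), although the entering group matches neither measured replacement. Compound 4 is estimated at 40 mL.min-1.g-1, with a range of 20 mL.min-1.g-1 to 80 mL.min-1.g-1.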

Compound 4, intrinsic clearance in microsomes: < 14 mL.min-1.g-1
Compound 4 gave a limit, no number; the forecaster's own chance of this, stated with the estimate: 5%; middle value at least 2.8-fold (0.45 log units) away from the limit.
By their numbers in this assay, from the lowest: compounds 1, 2 and 3 (each within the scatter of the next, the first and the last beyond it). At a limit, below all of these: compound 4.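

Compound 4 reads in this assay as a limit, < 14 mL.min-1.g-1, not as a number. Within the data shown here, this is the first replacement at this carbon that raises nothing: an at least 3.1-fold lower number from compound 3 to compound 4 (0.49 log units; beyond the scatter) is a step beyond the scatter, so a group with a six-membered aromatic ring of carbon added to its five-membered one is compatible with slow clearance here. Against the other two, an at least 1.4-fold lower number from compound 1 to compound 4 (0.15 log units; that floor lies within the scatter) and an at least 1.7-fold lower number from compound 2 to compound 4 (0.25 log units; that floor lies within the scatter) have floors within the scatter, so neither step is firm on its own.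

On these data alone, what stays open is how far compound 4 lies under its limit, and whether the methyl on the 2-methyl-1,3-benzoxazol-5-yl group matters. As far as these compounds go, how an amine or a carboxylic acid at this carbon would read is also open.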